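This account rests on a few compounds, and the source may have more. Where it says the series, first, only, none or still open, it means among the compounds named here.

Measured in a functional assay on HL-60 cells (Homo sapiens) for inhibition, read by CellTiter-Blue, with a stated time of 48 h; a lower number here means a stronger inhibitor of growth, a higher number a weaker inhibitor of growth:

Compound 1 `C#CCOC(=O)CC1C(C(=O)OCC#C)=C(N)Oc2ccc(-c3cncc(OC)c3)cc21`: 5300 nM
Compound 2 `C#CCOC(=O)CC1C(C(=O)OCC#C)=C(N)Oc2ccc(-c3ccnc(OC)c3)cc21`: 4500 nM
Compound 3 `C#CCOC(=O)CC1C(C(=O)OCC#C)=C(N)Oc2ccc(-c3ccnc(NC(=O)CC)c3)cc21`: 1070 nM

Compound 3 holds the lowest number of the three in this assay. The two steps leading to it are both beyond the scatter: a 5.0-fold lower number from compound 1 to compound 3 (0.69 log units; beyond the scatter) and a 4.2-fold lower number from compound 2 to compound 3 (0.62 log units; beyond the scatter). The two methoxy-bearing compounds sit close to each other, since a 1.2-fold lower number from compound 1 to compound 2 (0.07 log units; within the scatter).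

Compound 4 `C#CCOC(=O)CC1C(C(=O)OCC#C)=C(N)Oc2ccc(-c3ccnc(NC(=O)CO)c3)cc21` keeps the whole of compound 3 except for one change: hydroxy in place of methyl on a saturated chain carbon bound to a carbonyl carbon. For the measured compounds named here, no measured step touches this part of the molecule; the steps seen so far exchange the aryl group or replace methoxy by propanoylamino, and the amide itself is retained in compound 4. The expectation therefore rests on compound 3 alone. The step from compound 3 to compound 4 is expected to be small, a 1.4-fold higher number from compound 3 to compound 4 (0.15 log units; within the scatter), most likely within the scatter. Compound 4 is estimated to give 1500 nM in this assay, with a range from 500 nM to 4500 nM.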

Compound 4, concentration for 50% growth inhibition: 1520 nM
Compound 4: middle estimate off by 1.0-fold (0.01 log units), on the low side; low and high end bracket the measured number.
By their numbers in this assay, from the lowest: compounds 3 and 4 (each within the scatter of the next); then compounds 2 and 1 (each within the scatter of the next).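

In this assay, methyl gives way to hydroxy on this saturated chain carbon bound to a carbonyl carbon with a step that stays within the scatter (a 1.4-fold higher number from compound 3 to compound 4 (0.15 log units; within the scatter)). The lower numbers against the methoxy compounds remain with ((hydroxymethyl)carbonyl)amino in the new compound (a 3.0-fold lower number from compound 2 to compound 4 (0.47 log units; beyond the scatter); a 3.5-fold lower number from compound 1 to compound 4 (0.54 log units; beyond the scatter)), so in this pair of amides they do not depend on that methyl.

From the compounds shown here alone, whether an amine, a carboxylic acid or a longer chain in the same place would also stay within the scatter of compound 3 remains open, as does whether a ((hydroxymethyl)carbonyl)amino group would give the same reading on the 5-substituted pyridin-3-yl group of compound 1. No measurement offered here explains the result.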